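Methoxy added to the core of compound 1

A few compounds are considered here, and "the series" means these few. Any claim that something is new, unique, unknown or untested is made for them only; others in the source may bear on it.

Among the compounds with values here, in a functional assay on SW-620 cells (Homo sapiens) for cytotoxicity (on this read-out higher numbers stand for weaker inhibition and lower numbers for stronger inhibition), compound 1 `O=C(CCCCCCC(=O)Nc1nc2ccccc2s1)NO` gives 4.01 ug/mL as the lowest number measured so far. Compound 3 `CCOc1ccc2nc(NC(=O)CCCCC(=O)NO)sc2c1` has a shorter chain and gives a higher number (9.26 ug/mL). Compound 2 `O=C(CCCCC(=O)Nc1nc2ccc([N+](=O)[O-])cc2s1)NO` has the same shorter chain and is reported only as a limit (> 30 ug/mL).

Compound 4 `COc1ccc2nc(NC(=O)CCCCCCC(=O)NO)sc2c1` keeps the chain of compound 1 and carries methoxy in place of hydrogen on an aromatic carbon. Within the data shown here, no measured step makes this replacement. The closest is an at least 3.2-fold lower number from compound 2 to compound 3 (0.51 log units; beyond the scatter), where ethoxy replaces nitro on the shorter chain. That step starts from a limit (the limit of > 30 ug/mL in this assay, at which 1 of the 3 values shown sits), so it gives no size for replacing hydrogen. Among the measured compounds shown here, it shows only that compound 3 retains a measurable number (9.26 ug/mL) with ethoxy on the core. No step beyond the scatter is therefore expected, although the uncertainty is wide. The expected step is a 1.2-fold higher number from compound 1 to compound 4 (0.08 log units; within the scatter) as a best estimate. For compound 4 the estimated value is 4.8 ug/mL with an expected range from 1.8 ug/mL to 12 ug/mL in this read-out.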

Compound 4, half-maximal inhibitory concentration: 0.96 ug/mL
Beside the measured number, compound 4's estimate is 5.0-fold (0.70 log units) above it, outside the stated range (below it).
By their numbers in this assay, from the lowest: compound 4; then compound 1; then compound 3. At a limit, above all of these: compound 2.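

In this assay, within the data shown here, methoxy in place of hydrogen on an aromatic carbon of the shared core gives a 4.2-fold lower number from compound 1 to compound 4 (0.62 log units; beyond the scatter), the first sized step for replacing hydrogen at this position. The earlier step at this position started from a limit and gave no such size; this one shows that an added group here can lower the number on the chain of compound 1, and by more than the scatter. Nothing shown gives a reason for this step.

Open, going by these compounds, is whether the lower number holds for other groups on this carbon, such as an amine, a carboxylic acid or a hydroxyl. Also open, on these data alone, is whether methoxy gives a step of similar size on the shorter chain, or on the other aromatic carbons of the core.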